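A few compounds are considered here, and "the series" means these few. Any claim that something is new, unique, unknown or untested is made for them only; others in the source may bear on it.

Measured compounds in this series:

- compound 1 `COc1cccc2c1c(C(=O)/C=C(\O)C(=O)O)cn2Cc1cccc(F)c1` — 65800 nM
- compound 2 `CCOC(=O)/C(O)=C/C(=O)c1cn(Cc2cccc(F)c2)c2cccc(OC)c12` — 63200 nM
- compound 3 `CCOC(=O)/C(O)=C/C(=O)c1cn(Cc2cc(F)c(F)c(F)c2)c2cccc(OC)c12` — 33400 nM

In an ADME assay on MT4 cells (Homo sapiens) for cytotoxicity, read by MTT assay (on this read-out higher numbers stand for lower toxicity in this test and lower numbers for higher toxicity in this test), compound 1 sits at the top of the three numbers shown, yet no gap separates it from the others beyond the scatter: a 1.0-fold lower number from compound 1 to compound 2 (0.02 log units; within the scatter), and a 1.9-fold lower number from compound 2 to compound 3 (0.28 log units; within the scatter). Compound 3 gives 33400 nM, and compound 1 gives 65800 nM, a gap that also lies within the scatter. The compounds shown thus give much the same read-out in this assay.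

Compound 4 `COc1cccc2c1c(C(=O)/C=C(\O)C(=O)O)cn2Cc1ccc(F)cc1` is not yet measured. It differs from compound 1 in one place: 4-fluorophenyl in place of 3-fluorophenyl on a saturated chain carbon bound to an aromatic nitrogen. Within the data shown here, the one measured step at the same place, the step from compound 2 to compound 3, also swapped the group on the saturated chain carbon bound to the aromatic nitrogen and stayed within the scatter. The step from compound 1 to compound 2, at a different place, stayed within the scatter too. Nothing in the measured steps points to a change beyond the scatter for this swap, in either direction.

Compound 4 is therefore expected to give about 60000 nM in this assay, with a range of 30000 nM to 120000 nM. The step from compound 1 to compound 4 is estimated as a 1.1-fold lower number from compound 1 to compound 4 (0.04 log units; within the scatter).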

Compound 4, half-maximal cytotoxic concentration: 41100 nM
Estimate against measurement, compound 4: 1.5-fold (0.16 log units) above, within the range that was stated.
By their numbers in this assay, from the lowest: compounds 3, 4, 2 and 1 (each within the scatter of the next).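

In this assay, 4-fluorophenyl in place of 3-fluorophenyl on a saturated chain carbon bound to an aromatic nitrogen gives a 1.6-fold lower number from compound 1 to compound 4 (0.20 log units; within the scatter) and does not take the read-out beyond the scatter. Among these compounds, this is the first step at this position in which the atoms stay the same and only their joining differs, and the first at this position on a compound without the ethyl group, so the earlier insensitivity, seen only for the change from 3-fluorophenyl to 3,4,5-trifluorophenyl on the ethyl ester, now also holds for this swap on a second compound. No measurement in hand bears on why the read-out stays within the scatter at this position.

All the groups shown at this position are fluorinated phenyl rings on the same saturated carbon, so what a pyridine ring, a methoxy or nitrile on the phenyl ring, or a longer chain between ring and nitrogen would do in this assay stays open. Also open, on these data alone, is whether 4-fluorobenzyl on the ethyl ester would behave as it does on compound 4, and whether anything other than methoxy on the shared core would shift this read-out beyond the scatter.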